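Naphthyl for Chlorophenyl on the Thiazolone Core

The source may hold more compounds than are shown below. What is called first, only, known or untested is meant among the compounds shown, and "the series" means these compounds.

Compound 1 `O=C1N=C(c2ccc(Oc3ccccc3)cc2)S/C1=C\c1ccc(Oc2ccccc2)cc1`: 90 nM
Compound 2 `O=C1N=C(c2ccc(Cl)cc2)S/C1=C\c1ccc(OCc2ccccc2)cc1`: 80 nM
Compound 3 `O=C1N=C(c2ccc(Cl)cc2)S/C1=C\c1ccc(Oc2ccccc2)cc1`: 80 nM

In an assay on PMNL cells for inhibition of Polyunsaturated fatty acid 5-lipoxygenase (Homo sapiens), read by HPLC, with stated times of 15 min and 10 min (on this read-out lower numbers stand for stronger inhibition and higher numbers for weaker inhibition), compound 3 gives 80 nM, level with compound 2 at the digits shown and together with it the lowest of the three numbers; compound 1 sits within the scatter of it. The two measured steps, a 1.1-fold lower number from compound 1 to compound 3 (0.05 log units; within the scatter) and no change at the digits printed from compound 2 to compound 3 (within the scatter), both change a group on an aromatic ring and both stay within the scatter. Compound 4 `O=C1N=C(c2ccc3ccccc3c2)S/C1=C\c1ccc(Oc2ccccc2)cc1` differs from compound 3 by naphthalen-2-yl in place of 4-chlorophenyl on a carbon with a double bond to nitrogen. For the measured compounds named here, no measured step touches this position, so the prior steps give no direction; the expectation is a change within the scatter, a 1.3-fold higher number from compound 3 to compound 4 (0.10 log units; within the scatter). Compound 4 is therefore estimated at 100 nM, in the range 40 nM to 250 nM.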

Compound 4, half-maximal inhibitory concentration: 60 nM
The estimate for compound 4 lay 1.7-fold (0.22 log units) above the measured number, within the range that was stated.
By their numbers in this assay, from the lowest: compounds 4, 2, 3 and 1 (each within the scatter of the next).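

Putting naphthalen-2-yl in place of the whole 4-chlorophenyl on the carbon with a double bond to nitrogen gives, in this assay, a 1.3-fold lower number from compound 3 to compound 4 (0.12 log units; within the scatter). This position therefore takes a second six-membered aromatic ring of carbon only, and the number stays within the scatter. No supporting evidence bears on this result.

The compounds shown leave open how this position responds to a ring bearing an amine or a carboxylic acid. A pyridine ring or a small methyl group there also remains an open question.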